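The source may report more compounds than this note shows. Statements on the series, on what has been measured and on what is new or still open speak of the compounds shown alone.

The stomach of the rat is the setting for a functional assay on the whole organism (stomach) with Rattus norvegicus as the target (a lower number here means that less compound is needed, a higher number that more compound is needed for the effect), and the compounds here share one core, a saturated chain linking a ring nitrogen to a cyanoguanidine-type group.

Compound 1, `C/N=C(/NC#N)NCCCCn1nc(N(C)C)ccc1=O`, gives only a limit in this assay, > 100 mg/kg. Compound 2, `CN(C)/C(=N/CCCCn1nc(-c2ccccc2)ccc1=O)NC#N`, gives 30.3 mg/kg in this assay. Going by the values given here, compound 2 thus stands as the only compound with an actual number, since the other value shown is a limit; the limit is marked by the limit of > 100 mg/kg in this assay, at which 1 of the 2 values shown sits.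

Compound 3, `N#CNC(=N)NCCCCn1nc(-c2ccccc2)ccc1=O`, is not yet measured. It differs from compound 2 by a group of 6 heavy atoms (2 carbon, 4 nitrogen; no ring) in place of a group of 8 heavy atoms (4 carbon, 4 nitrogen; no ring), on a saturated chain carbon, four bonds along the chain from an aromatic nitrogen. The methyl groups on the outer nitrogen are gone, leaving more hydrogen-bond donors in their place, while the phenyl-bearing core stays.

Among the compounds with values here, with no measured step of this kind to lean on, a small change is expected, at most beyond the scatter in the direction of needing somewhat less compound, so that the step of a 1.4-fold lower number from compound 2 to compound 3 (0.14 log units; within the scatter) is estimated. Compound 3 is thus expected to give about 22 mg/kg in this assay, most plausibly between 7 mg/kg and 80 mg/kg.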

Compound 3, dose for half-maximal effect: 77.2 mg/kg
Compound 3: middle estimate off by 3.5-fold (0.55 log units), on the low side; the measured number falls inside the stated range.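

In this assay, the group of 6 heavy atoms (2 carbon, 4 nitrogen; no ring) in place of the group of 8 heavy atoms (4 carbon, 4 nitrogen; no ring) gives a 2.5-fold higher number from compound 2 to compound 3 (0.41 log units; beyond the scatter). Going by these compounds alone, compounds 1 and 2 differ in more than one place, so this is the first reading of a change in this group alone, with the phenyl-bearing core held fixed, and it shows that losing the two methyl groups raises the dose needed by a modest margin. Nothing measured here explains this step.

One step cannot show whether a single methyl group on the phenyl-bearing core would behave like the two methyl groups or like none. On these data alone, the effect of ethyl groups in their place, or of a longer chain, also remains open.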